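From compound 1 to compound 4: a larger carbon group

The compounds below may be only part of what the source reports. "The series", "measured", "known", "first", "only" and "open" are said of these compounds alone.

Measured in a functional assay on MDA-MB-231 cells (Homo sapiens) for cytotoxicity, read by MTT assay, with a stated time of 48 h; on this read-out higher numbers stand for an effect only at larger amounts of compound and lower numbers for an effect already at smaller amounts:
- compound 1 `CO[C@H]1O[C@H](COc2cccc3c2CCCC3)[C@@H](O)[C@H](O)[C@H]1Oc1ccc(OC2CCCCC2)cc1` gives "not determined" (no result reported)
- compound 2 `CO[C@@H]1O[C@H](COc2ccc3c(c2)CCCC3)[C@@H](O)[C@H](O)[C@H]1Oc1ccc(OC2CCCCC2)cc1` gives "not determined" (no result reported)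
- compound 3 `CO[C@@H]1O[C@H](COc2ccc(-c3ccccc3)cc2)[C@@H](O)[C@H](O)[C@H]1Oc1ccc(OC2CCCCC2)cc1` gives 36000 nM

Compound 1 has no place on the numerical scale of this assay, since no single number was reported for it. For the measured compounds named here, the same is true of compound 2, so compound 3 provides the only number in the set. The step of interest starts from compound 1 and leads to compound 4 `CO[C@H]1O[C@H](COc2ccc(C3CCCCC3)cc2)[C@@H](O)[C@H](O)[C@H]1Oc1ccc(OC2CCCCC2)cc1`, which carries 4-cyclohexylphenyl in place of 1,2,3,4-tetrahydronaphthalen-5-yl on an oxygen on a saturated carbon.

With no number for compound 1, the size and direction of this step cannot be read from the data. Going by the values given here, the only anchor is compound 3 at 36000 nM, and compound 4 is expected to differ from it by no more than the usual scatter, with no direction favoured. For compound 4 the estimated value is 35000 nM, with an expected range of 12000 nM to 100000 nM.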

Compound 4, half-maximal effective concentration: 14000 nM
Compound 4: the middle estimate sits 2.5-fold (0.40 log units) above what was measured, within the range that was stated.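

No step can be read from compound 1 to compound 4: in this assay compound 4 gives 14000 nM, while compound 1 has no single number. The compounds shown leave open how 4-cyclohexylphenyl compares with 1,2,3,4-tetrahydronaphthalen-5-yl on this scale. No measured evidence bears on this result.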